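The compounds below may be only part of what the source reports. "The series", "measured", "known", "first", "only" and "open" are said of these compounds alone.

The series centres on amides that close a six-membered aromatic ring onto a nitrogen-bearing heterocycle. Compound 1, `Cc1csc(NC(=O)c2cccc(Cl)c2)n1`, was tested in a functional assay on CHO cells for antagonist activity at metabotropic glutamate receptor 5 (Homo sapiens), read by inositol phosphate accumulation (on this read-out lower numbers stand for stronger inhibition and higher numbers for weaker inhibition), where compound 1 gives 15000 nM, a weak result on this read-out. Compound 2, `Cc1cccc(NC(=O)c2cccc(C(F)(F)F)c2)n1`, shares the amide link and the carbon ring with compound 1 but carries a different heterocycle and a trifluoromethyl group; for compound 2 the outcome in this assay is "not determined" (no result reported), so compound 2 stands on no number at all, and nothing can be said about where it sits relative to compound 1.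

Compound 3, `Cc1cccc(NC(=O)c2cccc(C#N)c2)n1`, is the next point. The change from compound 2 to compound 3 is cyano in place of trifluoromethyl on an aromatic carbon. Among the measured compounds shown here, since compound 2 has no value, no step of any size can be measured here; the expectation rests only on compound 1 and the structural change. On these data alone, compound 3 is estimated to give 5000 nM in this assay, within a range from 800 nM to 30000 nM, and this estimate remains open until the measurement is made.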

Compound 3, half-maximal inhibitory concentration: 5330 nM
The estimate for compound 3 lay 1.1-fold (0.03 log units) below the measured number; low and high end bracket the measured number.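

No new step can be read from compound 2 to compound 3, and compound 1 differs from compound 3 in more than one place. The compounds shown leave open how cyano and trifluoromethyl compare on the shared core in this assay. No evidence bearing on this result is available.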